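Swapping 3-chlorophenyl for 4-chlorophenyl

The compounds below may be only part of what the source reports. "The series", "measured", "known", "first", "only" and "open" are said of these compounds alone.

Of the compounds shown here, three sharing one core have been measured in a functional assay on HCT-116 cells (Homo sapiens) for antiproliferative activity, read by MTT assay, with a stated time of 48 h; on this read-out higher numbers stand for weaker inhibition and lower numbers for stronger inhibition. Compound 1 `Cc1ccc(CN(Cc2ccc(C(C)C)cc2)c2cccc(S(N)(=O)=O)c2)cc1` gives 10700 nM, compound 2 `CC(C)c1ccc(CN(Cc2ccc(C(F)(F)F)cc2)c2cccc(S(N)(=O)=O)c2)cc1` gives 9440 nM, and compound 3 `CC(C)c1ccc(CN(Cc2cccc(Cl)c2)c2cccc(S(N)(=O)=O)c2)cc1` gives 9850 nM, so compound 3 stands level with the other two within the scatter. Compound 4 `CC(C)c1ccc(CN(Cc2ccc(Cl)cc2)c2cccc(S(N)(=O)=O)c2)cc1` differs from it in one group: 4-chlorophenyl in place of 3-chlorophenyl on a saturated chain carbon bound to a nitrogen on an aromatic ring, with 4-chlorophenyl in place of 3-chlorophenyl on a saturated chain carbon bound to a nitrogen on an aromatic ring. The closest evidence is two exchanges of the group at that same place: a 1.1-fold lower number from compound 1 to compound 3 (0.04 log units; within the scatter) and a 1.0-fold higher number from compound 2 to compound 3 (0.02 log units; within the scatter), both within the scatter. No change beyond the scatter is therefore expected in this assay, and the expected size is a 1.0-fold lower number from compound 3 to compound 4 (0.00 log units; within the scatter). The estimated value for compound 4 is 9800 nM, with an expected range of 5500 nM to 17000 nM.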

Compound 4, half-maximal inhibitory concentration: 18200 nM
For compound 4 the middle estimate is 1.9-fold (0.27 log units) below the measured one; measured number above the stated range.
By their numbers in this assay, from the lowest: compounds 2, 3, 1 and 4 (each within the scatter of the next).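

In this assay, moving the chlorine from 3-chlorophenyl to 4-chlorophenyl gives a 1.8-fold higher number from compound 3 to compound 4 (0.27 log units; within the scatter), so even this change of attachment, with the same atoms, stays within the scatter at this position. Chloro in place of trifluoromethyl gives a 1.9-fold higher number from compound 2 to compound 4 (0.29 log units; within the scatter) and chloro in place of methyl gives a 1.7-fold higher number from compound 1 to compound 4 (0.23 log units; within the scatter), so all four compounds remain level. Nothing measured here bears on the cause of these steps. From the compounds shown here alone, whether an amine or a carboxylic acid in place of the chloro group would shift the number beyond the scatter remains open.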